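The compounds below may be only part of what the source reports. "The series", "measured", "known", "first", "only" and "open" are said of these compounds alone.

Working notes on the series. Among the measured compounds shown here, in a functional assay on L1210 cells (Mus musculus) for antiproliferative activity (on this read-out lower numbers stand for stronger inhibition and higher numbers for weaker inhibition), compound 2 (`COc1cc(C(=O)c2sc(-c3cccs3)cc2N)cc(OC)c1OC`) gives 9.8 nM and holds the lower of the two numbers so far. In this assay, for the measured compounds named here, compound 1 (`COc1cc(C(=O)c2sc(-c3ccc(Br)cc3)cc2N)cc(OC)c1OC`) gives 100 nM as the only other number. Compound 3 (`CCOc1ccc(-c2cc(N)c(C(=O)c3cc(OC)c(OC)c(OC)c3)s2)cc1`) keeps the shared core and puts 4-ethoxyphenyl in place of thiophen-2-yl (4-ethoxyphenyl in place of thiophen-2-yl on an aromatic carbon) on the aromatic carbon next to the ring sulfur. Going by the values given here, the one measured step at this place (a 10-fold lower number from compound 1 to compound 2 (1.01 log units; beyond the scatter)) is large and beyond the scatter, and it replaced 4-bromophenyl with thiophen-2-yl. Compound 3 brings back a six-membered aromatic ring of carbon only, as in compound 1, but with a different group on it. Among the compounds with values here, no 4-ethoxyphenyl analogue has been measured, so how much of that step returns remains open. A move to a higher number is expected, of a size up to that of the measured step and probably smaller. The expected change (a 4.1-fold higher number from compound 2 to compound 3 (0.61 log units; beyond the scatter)) is therefore a moderate loss with wide uncertainty. Compound 3 is estimated at 40 nM with an expected range from 10 nM to 160 nM in these notes.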

Compound 3, half-maximal inhibitory concentration: 590 nM
Compound 3: the middle estimate sits 15-fold (1.17 log units) below what was measured, and the stated range ends below it.
By their numbers in this assay, from the lowest: compound 2; then compound 1; then compound 3.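

In this assay, the place next to the ring sulfur proves sensitive to more than one kind of change: the exchange of thiophen-2-yl for 4-ethoxyphenyl gives a 60-fold higher number from compound 2 to compound 3 (1.78 log units; beyond the scatter), and thiophen-2-yl now holds the lowest number against both six-membered aromatic rings of carbon only. The ring type does not settle the number alone, since the group carried on that ring also counts: ethoxy in place of bromo gives a 5.9-fold higher number from compound 1 to compound 3 (0.77 log units; beyond the scatter), a modest step but one beyond the scatter. Nothing available accounts for either step.

With only one five-membered aromatic ring and two substituted six-membered rings at this place, the compounds shown do not separate the contribution of the ring from that of the group on it, and an unsubstituted phenyl or a furan-2-yl would bear directly on that question. As far as these compounds go, it also remains open whether the number continues to rise with a longer chain such as butoxy in place of ethoxy, or how a dimethylamino group in that same place would compare with bromo and ethoxy.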